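Benzyl for Cyclohexyl on a Second Amide Series

This account rests on a few compounds, and the source may have more. Where it says the series, first, only, none or still open, it means among the compounds named here.

Compound 1 `COc1ccc(-c2cc(NC(=O)CCC(=O)NCC(=O)NC3CCCCC3)nc(-c3ccc(OC)cc3)n2)cc1`: 35100 nM
Compound 2 `COc1ccc(-c2cc(NC(=O)CCC(=O)NCC(=O)NCc3ccccc3)nc(-c3ccc(OC)cc3)n2)cc1`: 26900 nM
Compound 3 `COc1ccc(-c2cc(NC(=O)CCC(=O)N3CCN(CC(=O)NC4CCCCC4)CC3)nc(-c3ccc(OC)cc3)n2)cc1`: 10500 nM

In an assay on HeLa cells for displacement of a labelled ligand from adenosine receptor A3 (Homo sapiens), read by fluorescence polarization, with a stated time of 30 min (on this read-out lower numbers stand for stronger inhibition and higher numbers for weaker inhibition), compound 1 gives 35100 nM and compound 2 gives 26900 nM. The step of a 1.3-fold lower number from compound 1 to compound 2 (0.12 log units; within the scatter) corresponds to benzyl in place of cyclohexyl on an amide-type nitrogen. Compound 3 gives 10500 nM in this assay, the lowest of the three numbers; how its core differs from that of compound 1 is not broken down here. Compound 4 `COc1ccc(-c2cc(NC(=O)CCC(=O)N3CCN(CC(=O)NCc4ccccc4)CC3)nc(-c3ccc(OC)cc3)n2)cc1` is obtained from compound 3 by benzyl in place of cyclohexyl on an amide-type nitrogen, the same change as that made between compound 1 and compound 2, at the same kind of amide-type nitrogen. Resting on a 1.3-fold lower number from compound 1 to compound 2 (0.12 log units; within the scatter), the expected step is a 1.2-fold lower number from compound 3 to compound 4 (0.09 log units; within the scatter). Compound 4 is therefore expected to give 8500 nM in this assay, with a likely range from 4000 nM to 18000 nM.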

Compound 4, inhibition constant: 3400 nM
Compound 4: middle estimate off by 2.5-fold (0.40 log units), on the high side; measured number outside the range, below it.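

In this assay, benzyl in place of cyclohexyl on an amide-type nitrogen gives a 3.1-fold lower number from compound 3 to compound 4 (0.49 log units; beyond the scatter). Set beside the same change on the core of compound 1, this step cannot be told apart in size from the earlier one: the same change on two cores in this assay, a 1.3-fold lower number (0.12 log units; within the scatter) from compound 1 to compound 2 and a 3.1-fold lower number (0.49 log units; beyond the scatter) from compound 3 to compound 4, 2.4-fold (0.37 log units) apart, within the scatter of two such steps. Going by these compounds alone, this suggests that the change can be carried between these two cores, but it does not show a constant step: only two pairs are at hand, and only the one on the core of compound 3 lies beyond the scatter.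

The compounds shown leave open how a phenyl or a phenethyl group on the same amide-type nitrogen would read. Also open, on these data alone, is what an amine or a carboxylic acid on the benzyl ring would do to the number.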